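This account rests on a few compounds, and the source may have more. Where it says the series, first, only, none or still open, it means among the compounds named here.

In a functional assay on MIA PaCa-2 cells (Homo sapiens) for antiproliferative activity, read by MTT assay, with a stated time of 72 h (on this read-out higher numbers stand for an effect only at larger amounts of compound and lower numbers for an effect already at smaller amounts), compound 1 `Cc1nn(Cc2ccc(C(N)=O)cc2)c(C)c1NC(=O)c1ccc(COc2ccccc2)cc1` gives only a limit, > 100000 nM. Within the data shown here, compound 2 `Cc1nn(Cc2cccc(C(N)=O)c2)c(C)c1NC(=O)c1ccc(COc2ccccc2)cc1` gives 9200 nM, and the single change between them brought an at least 10-fold lower number from compound 1 to compound 2 (1.03 log units; beyond the scatter). Among the measured compounds shown here, compound 3 `CNC(=O)c1cccc(Cn2nc(C)c(NC(=O)c3ccc(COc4ccccc4C)cc3)c2C)c1` gives 2100 nM and stands lowest of the two numbers known in this assay; compound 2 differs from it in two places at once, so those two values can only be set side by side, not traced to one change. Compound 4 `CNC(=O)c1cccc(Cn2nc(C)c(NC(=O)c3ccc(COc4ccc(C(F)(F)F)cc4)cc3)c2C)c1` differs from compound 3 in one place: 4-(trifluoromethyl)phenyl in place of 2-methylphenyl on an oxygen on a saturated carbon. For the measured compounds named here, no measured step touches this part of the molecule, so nothing beyond the scatter is expected. For compound 4 the expected step is a 1.1-fold lower number from compound 3 to compound 4 (0.02 log units; within the scatter). Compound 4 is therefore estimated at 2000 nM, between 500 nM and 8000 nM.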

Compound 4, half-maximal effective concentration: 800 nM
Estimate against measurement, compound 4: 2.5-fold (0.40 log units) above; the range from low to high includes it.
By their numbers in this assay, from the lowest: compound 4; then compound 3; then compound 2. At a limit, above all of these: compound 1.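

Among these compounds, the only single change measured before this one moved the carbamoyl group. Among the compounds shown here, this is the first to touch the group on an oxygen on a saturated carbon: in this assay, 4-(trifluoromethyl)phenyl in place of 2-methylphenyl brings a 2.6-fold lower number from compound 3 to compound 4 (0.42 log units; beyond the scatter). So this part of the molecule can also shift the number beyond the scatter, though the step is modest and rests on a single pair.

Going by these compounds, it stays open whether losing the 2-methyl or gaining the 4-(trifluoromethyl) matters, and what an amine or a carboxylic acid on that phenyl ring would do. Nothing given here explains why this change lowers the number.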